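This account rests on a few compounds, and the source may have more. Where it says the series, first, only, none or still open, it means among the compounds named here.

Measured so far, in an assay on HEK293 cells for displacement of a labelled ligand from Urotensin-2 receptor (Homo sapiens), read by fluorescence, with a stated time of 90 min; a lower number here means a stronger inhibitor, a higher number a weaker inhibitor:
- compound 1 `O=C(NC1CCN(Cc2ccc(OC3CCNCC3)c(Br)c2)CC1)c1ccco1`: 770 nM
- compound 2 `O=C(NC1CCN(Cc2ccc(OC3CCNCC3)c(Br)c2)CC1)c1ccccn1`: 120 nM

The two compounds share one core and differ only in the group on the carbonyl carbon. Going by the values given here, the single step between them, a 6.4-fold lower number from compound 1 to compound 2 (0.81 log units; beyond the scatter), is beyond the scatter and leaves compound 2 with the lowest of the two numbers, compound 1 being its nearest neighbour at the higher value.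

Compound 3 `O=C(NC1CCN(Cc2ccc(OC3CCNCC3)c(Br)c2)CC1)c1cc2ccccc2s1` carries the change (1-benzothiophen-2-yl in place of pyridin-2-yl on a carbonyl carbon). Among the compounds with values here, no measured step exchanges a six-membered aromatic ring for a fused bicyclic one at this position; the only step available, a 6.4-fold lower number from compound 1 to compound 2 (0.81 log units; beyond the scatter), concerns a different exchange on the same carbonyl carbon and shows that this position can shift the number by a modest amount. With no closer comparison, the expected step in this assay from compound 2 to compound 3 is a 1.5-fold higher number from compound 2 to compound 3 (0.18 log units; within the scatter), that is, no change clearly beyond the scatter, but with a wide range in both directions. Compound 3 is therefore estimated at 180 nM, with a range from 40 nM to 900 nM.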

Compound 3, half-maximal inhibitory concentration: 63 nM
Compound 3: the middle estimate sits 2.9-fold (0.46 log units) above what was measured; low and high end bracket the measured number.
By their numbers in this assay, from the lowest: compounds 3 and 2 (each within the scatter of the next); then compound 1.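

In this assay, 1-benzothiophen-2-yl in place of pyridin-2-yl on the carbonyl carbon gives a 1.9-fold lower number from compound 2 to compound 3 (0.28 log units; within the scatter), so this position takes a group of 9 heavy atoms with sulfur and no nitrogen without a step beyond the scatter, and compound 2 and compound 3 cannot be told apart here. Set against furan-2-yl, the same group gives a 12-fold lower number from compound 1 to compound 3 (1.09 log units; beyond the scatter), which means that of the three groups only furan-2-yl stands apart, with both compound 2 and compound 3 beyond the scatter from compound 1. No outside evidence bears on this result.

On these data alone, how phenyl or thiophen-2-yl on the same carbonyl carbon would compare remains open, and with it whether the gap to compound 1 follows the number of rings, the ring size or the hetero atom. Also open, as far as these compounds go, is whether the picture at this position holds when the bromine of the shared core gives way to chlorine or a methyl group.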